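This account rests on a few compounds, and the source may have more. Where it says the series, first, only, none or still open, it means among the compounds named here.

Of the compounds shown here, three built on one shared core have been tested in a functional assay on HL-60 cells (Homo sapiens) for antiproliferative activity, tested at 20 uM; a higher number here means a stronger effect of the compound at the concentration tested, a lower number a weaker effect. Compound 1 `Cc1cc2cc(NC(=O)c3ccc(S(=O)(=O)Nc4ccc5c(c4)cc(C)c(=O)n5C)cc3)ccc2n(C)c1=O` gives 55%, compound 2 `COC(=O)c1ccc(OC)c(S(=O)(=O)Nc2ccc3c(c2)cc(C)c(=O)n3C)c1` gives 44%, and compound 3 `COc1cc(C(=O)NO)ccc1CS(=O)(=O)Nc1ccc2c(c1)cc(C)c(=O)n2C` gives 0%. Compound 2 thus stands second highest of the three: compound 1 sits above it by a margin beyond the usual scatter, and compound 3 sits far below it, also beyond the scatter. Compound 4 `COc1ccc(C(=O)NOCc2ccccc2)cc1S(=O)(=O)Nc1ccc2c(c1)cc(C)c(=O)n2C` has not yet been measured. It differs from compound 2 in one place: (benzyloxy)amino in place of methoxy on a carbonyl carbon. Among the compounds with values here, no measured pair differs in just this way, so there is no measured step to lean on. The step expected in this assay, a number 6 percentage points lower from compound 2 to compound 4 (within the scatter), is small enough to stay within the scatter. Compound 4 is therefore estimated at 38%, with a range from 10% to 65%.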

Compound 4, a percentage reported as inhibition, at one concentration (the size of the read-out at that concentration, not a potency): 13%
Compound 4: the middle estimate sits 25 percentage points above what was measured, and the stated range covers the measured number.
By their numbers in this assay, from the lowest: compound 3; then compound 4; then compound 2; then compound 1.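

In this assay, putting (benzyloxy)amino in place of methoxy on the carbonyl carbon gives a number 31 percentage points lower from compound 2 to compound 4 (beyond the scatter), so the effect at the concentration tested depends on what sits at this position. The change adds a six-membered aromatic ring and a hydrogen-bond donor together, and this single pair cannot separate the two. Nothing measured here explains the drop.

As far as these compounds go, a carboxylic acid, a primary amide or a hydroxyamino group on this carbonyl carbon remains open. Any of these would show whether the loss follows the benzyl part or the nitrogen.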